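The compounds below may be only part of what the source reports. "The series", "measured", "known", "first", "only" and "open" are said of these compounds alone.

Compound 1 `CCCCNC(=O)Nc1cc2nc(C3CCCCC3)[nH]c2cc1N(CC)CC` gives in an ADME assay on Vero cells (Chlorocebus sabaeus) for cytotoxicity, read by resazurin assay, with a stated time of 3 days (a higher number here means a weaker inhibitor, a lower number a stronger inhibitor), a result of > 100 ug/mL, which is a limit of the assay and not a number.
Compound 2 `CCN(CC)c1cc2[nH]c(C3CCCCC3)nc2cc1NC(=O)c1cnccn1` gives in this assay > 100 ug/mL, again a limit of the assay.
Compound 3 `CCCc1ccc(C(=O)Nc2cc3nc(C4CCCCC4)[nH]c3cc2N(C)C)cc1` gives in this assay > 100 ug/mL, also a limit of the assay.

So compound 3 stands where every measured compound stands: at the limit of > 100 ug/mL in this assay, at which 3 of the 3 values shown sit. Going by the values given here, no compound here has a number, and the one pair that differs in a single place, the change from compound 1 to compound 2, gives a step that the two limits leave unreadable from compound 1 to compound 2, so its size cannot be read.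

Compound 4 `CCCOCC(=O)Nc1cc2nc(C3CCCCC3)[nH]c2cc1N(C)C` is reached from compound 3 by a single change: propoxymethyl in place of 4-propylphenyl on a carbonyl carbon. Among the compounds with values here, no measured step bears on this change, and the measured steps that exist cannot be read because both their ends sit at the limit of > 100 ug/mL in this assay, at which 3 of the 3 values shown sit. Within the data shown here, what is known is only that three compounds sharing this core, with different groups on the same carbonyl carbon, all reach the limit. Compound 4 is therefore expected to do the same, with an estimated 150 ug/mL lying between 80 ug/mL and 400 ug/mL. The step from compound 3 to compound 4 is expected to be a step that the limit leaves unreadable from compound 3 to compound 4, that is, none beyond the scatter.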

Compound 4, half-maximal inhibitory concentration: < 50 ug/mL
Compound 4 gave a limit, no number; the forecaster's own chance of this, stated with the estimate: 85%; at least 3.0-fold (0.47 log units) between middle value and limit.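

In this assay, compound 4 gives < 50 ug/mL, which is a limit of the assay and not a number. Putting propoxymethyl in place of 4-propylphenyl on the carbonyl carbon gives an at least 2.0-fold lower number from compound 3 to compound 4 (0.30 log units; that floor lies within the scatter), so a group at this position can take the result away from the upper limit, even though the size of the step stays uncertain. The earlier compounds could not show this, as changing the group there had produced no readable step and all of them sat at one limit: the limit of > 100 ug/mL in this assay, at which 3 of the 4 values shown sit.

This change removes a carbon ring and brings in an oxygen at once, leaving open which of the two goes with the lower number. Going by these compounds, a plain pentyl chain on the same carbonyl carbon would have the missing ring without the oxygen, and how far the true value of compound 4 lies from its limit also stays open.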